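The compounds below may be only part of what the source reports. "The series", "measured", "known", "first", "only" and "open" are said of these compounds alone.

Values in a functional assay on HOS cells (Homo sapiens) for antiproliferative activity, with a stated time of 72 h; a lower number here means a stronger inhibitor, a higher number a weaker inhibitor:
- compound 1 `OC[C@H]1O[C@@H](n2cnc3c(NCc4cccc(Br)c4)ncnc32)[C@H](O)[C@@H]1O`: > 166000 nM
- compound 2 `Cc1cccc(CNc2ncnc3c2ncn3[C@@H]2O[C@H](CO)[C@@H](O)[C@H]2O)c1`: > 166000 nM
- compound 3 `COc1cccc(CNc2ncnc3c2ncn3[C@@H]2O[C@H](CO)[C@@H](O)[C@H]2O)c1`: > 166000 nM

Within the data shown here, the whole series so far reads as the limit of > 166000 nM in this assay, at which 3 of the 3 values shown sit. Compound 3 has no number, only the limit > 166000 nM, and so has no rank against the other two.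

The next compound is compound 4 `OC[C@H]1O[C@@H](n2cnc3c(NCc4cccc(OC(F)(F)F)c4)ncnc32)[C@H](O)[C@@H]1O`. The change is trifluoromethyl in place of methyl on an oxygen on an aromatic ring, that is, methoxy to trifluoromethoxy, with trifluoromethyl in place of methyl on an oxygen on an aromatic ring.

The nearest measured changes each swap one group on an aromatic carbon: a step that the two limits leave unreadable from compound 2 to compound 3, a step that the two limits leave unreadable from compound 1 to compound 3 and a step that the two limits leave unreadable from compound 1 to compound 2. None of them gives a size or a direction. No measured swap in this series has yet brought a compound off the limit in this assay, so no step beyond the scatter is expected, and no direction can be argued. The most likely outcome for compound 4 is another limit rather than a number.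

Compound 4 is estimated at 166000 nM, with an expected range of 60000 nM to 300000 nM. The expected change is a number no higher from compound 3 to compound 4 (the limit leaves the size open).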

Compound 4, half-maximal inhibitory concentration: > 166000 nM
Compound 4: only a limit was reported; the forecaster's own chance of this, stated with the estimate: 80%; the middle value lies on the limit itself.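

In this assay compound 4 gives > 166000 nM, a limit and not a number. The steps from compound 1, compound 2 and compound 3 to compound 4 therefore cannot be read. The compounds shown leave open whether any one-group swap on the shared core gives a readable number in this assay, and how these four compounds rank.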